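Extending the chain of a chalcone-type sulfonylurea

The source may report more compounds than this note shows. Statements on the series, on what has been measured and on what is new or still open speak of the compounds shown alone.

Measured compounds:
compound 1, `Cc1ccc(S(=O)(=O)NC(=O)Nc2ccccc2C(=O)/C=C/c2ccc(O)cc2)cc1`, 24.3 ug/mL
compound 2, `CCOc1cc(/C=C/C(=O)c2ccccc2NC(=O)NS(=O)(=O)c2ccc(C)cc2)ccc1O`, 19.2 ug/mL
compound 3, `Cc1ccc(S(=O)(=O)NC(=O)Nc2ccccc2C(=O)/C=C/c2cccc([N+](=O)[O-])c2)cc1`, 44.5 ug/mL

All three were tested in an ADME assay on the whole organism for cytotoxicity, with Artemia salina as the target, with a stated time of 24 h; on this read-out higher numbers stand for an effect only at larger amounts of compound and lower numbers for an effect already at smaller amounts. Compound 1 holds the second highest of the three numbers. Its nearest neighbour is compound 2, with a 1.3-fold lower number from compound 1 to compound 2 (0.10 log units; within the scatter), and its furthest is compound 3, with a 1.8-fold higher number from compound 1 to compound 3 (0.26 log units; within the scatter); neither of these two steps reaches beyond the scatter. For the measured compounds named here, only the step of a 2.3-fold higher number from compound 2 to compound 3 (0.37 log units; beyond the scatter) is modest and beyond it.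

Compound 4, `Cc1ccc(S(=O)(=O)NC(=O)Nc2ccccc2C(=O)/C=C/C=C/c2ccccc2)cc1`, has not yet been measured. It differs from compound 1 as follows: 2-phenylethenyl in place of 4-hydroxyphenyl on a double-bonded chain carbon bound to a double-bonded chain carbon. The step from compound 1 to compound 3 also replaced the 4-hydroxyphenyl, with 3-nitrophenyl, and gave a number within the scatter. Going by the values given here, no measured step puts 2-phenylethenyl in that place, so the effect of lengthening the chain by one double bond is unknown here. On this basis compound 4 is expected to sit near compound 1, with a 1.2-fold higher number from compound 1 to compound 4 (0.06 log units; within the scatter), a step expected to stay within the scatter. The estimate for compound 4 in this assay is 28 ug/mL, with a range from 14 ug/mL to 56 ug/mL.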

Compound 4, concentration for half-maximal effect: 18.2 ug/mL
Compound 4: the middle estimate sits 1.5-fold (0.19 log units) above what was measured; the measured number falls inside the stated range.
By their numbers in this assay, from the lowest: compounds 4, 2, 1 and 3 (each within the scatter of the next, the first and the last beyond it).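

In this assay, the place on a double-bonded chain carbon bound to a double-bonded chain carbon takes 2-phenylethenyl, with its added double bond outside aromatic rings, and the number stays within the scatter of both hydroxylated compounds: a 1.3-fold lower number from compound 1 to compound 4 (0.13 log units; within the scatter) and a 1.1-fold lower number from compound 2 to compound 4 (0.02 log units; within the scatter). Against the 3-nitrophenyl compound the same group gives a modest step beyond the scatter, a 2.4-fold lower number from compound 3 to compound 4 (0.39 log units; beyond the scatter), so compound 3 now has two such steps, the other being a 2.3-fold higher number from compound 2 to compound 3 (0.37 log units; beyond the scatter), while its step from compound 1 stays within the scatter. No measurement is at hand that explains how these numbers arise.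

The change from compound 1 to compound 4 lengthens the chain and removes the hydroxy group at once, so the compounds shown cannot separate what each change does on its own. Also open, going by these compounds, is how this read-out would respond to a hydroxy group or an amine on the end ring of the 4-phenylbuta-1,3-dien-1-yl chain, or to a still longer chain of alternating double bonds.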